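Moving the Fluorine to a New Place on the Ring

The source may hold more compounds than are shown below. What is called first, only, known or untested is meant among the compounds shown, and "the series" means these compounds.

Compound 2, `CN1CCC[C@@H]1Cn1nc(Cc2ccc(F)cc2)c2ccccc2c1=O`, gives 63.1 nM in an assay for binding affinity to Alpha-1A adrenergic receptor (Homo sapiens); on this read-out higher numbers stand for weaker inhibition and lower numbers for stronger inhibition. Among the measured compounds shown here, that is the lowest of the two numbers measured so far; its only neighbour is compound 1, `CN1CCC[C@@H]1Cn1nc(Cc2ccc(O)cc2)c2ccccc2c1=O`, which gives 251 nM in this assay. For the measured compounds named here, the one measured step, a 4.0-fold lower number from compound 1 to compound 2 (0.60 log units; beyond the scatter), exchanges the group on the aromatic ring while keeping its place. Compound 3, `CN1CCC[C@@H]1Cn1nc(Cc2cccc(F)c2)c2ccccc2c1=O`, is a different kind of change: 3-fluorophenyl in place of 4-fluorophenyl on a saturated chain carbon bound to an aromatic carbon. The fluorine stays; only its place on that ring moves. Going by the values given here, no measured step concerns such a move, so the data give no direction for it; the step from compound 1 to compound 2 shows only that the ring substituent matters. The step expected for compound 3 is a 1.3-fold higher number from compound 2 to compound 3 (0.10 log units; within the scatter), nothing beyond the scatter, with the wide range reflecting this lack of guidance. Compound 3 is thus estimated at 80 nM, somewhere between 25 nM and 250 nM.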

Compound 3, inhibition constant: 50.1 nM
Compound 3: the middle estimate sits 1.6-fold (0.20 log units) above what was measured, within the range that was stated.
By their numbers in this assay, from the lowest: compounds 3 and 2 (each within the scatter of the next); then compound 1.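

In this assay, moving the fluorine from 4-fluorophenyl to 3-fluorophenyl gives a small shift that cannot be told from the scatter (a 1.3-fold lower number from compound 2 to compound 3 (0.10 log units; within the scatter)), so these two places on the ring are not distinguished by this read-out. The 3-fluorophenyl group also stands clearly apart from 4-hydroxyphenyl (a 5.0-fold lower number from compound 1 to compound 3 (0.70 log units; beyond the scatter)), which shows that among these three compounds the separation from compound 1 holds for fluorine at either place. Nothing available here explains why this move leaves the number within the scatter.

Going by these compounds, whether a chlorine, a methoxy group or a nitrile on this ring would give numbers like those of the fluorine remains open. So does the effect of a longer chain joining this ring to the shared core.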